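Replacing a chlorophenyl with a methylphenyl: expected tolerability

The compounds below may be only part of what the source reports. "The series", "measured", "known", "first", "only" and "open" are said of these compounds alone.

Three compounds have been measured in an ADME assay on PANC-1 cells (Homo sapiens) for cytotoxicity, read by MTT assay; a higher number here means that more compound is tolerated, a lower number that less compound is tolerated:
compound 1 `Cc1nc(-c2cccnc2)sc1-c1nnc(-c2ccccc2Cl)o1` with > 100 ug/mL;
compound 2 `Cc1nc(-c2cccnc2)sc1-c1nnc(-c2ccc(Cl)cc2)o1` with > 100 ug/mL;
compound 3 `Cc1nc(-c2cccnc2)sc1-c1nnc(-c2cccc(Cl)c2Cl)o1` with > 100 ug/mL.

The value of compound 1 is a limit of the assay, not a number. The same holds for compound 2. The same holds for compound 3. So compound 1 stands where all three sit, at the limit of > 100 ug/mL in this assay, at which 3 of the 3 values shown sit, and nothing separates it from the other two.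

The measured steps are a step that the two limits leave unreadable from compound 1 to compound 2, a step that the two limits leave unreadable from compound 1 to compound 3 and a step that the two limits leave unreadable from compound 2 to compound 3. Each swaps one chlorophenyl for another on the same carbon of the shared core, and none shows a readable size because all values sit at the limit of > 100 ug/mL in this assay, at which 3 of the 3 values shown sit.

Compound 4 `Cc1ccc(-c2nnc(-c3sc(-c4cccnc4)nc3C)o2)cc1` differs from compound 1 by 4-methylphenyl in place of 2-chlorophenyl on an aromatic carbon. The measured steps, all with unreadable size, bear on it only in that every aryl group tried here has stayed at the limit. Compound 4 is therefore expected to give 150 ug/mL, with a range of 60 ug/mL to 400 ug/mL. The step that the limit leaves unreadable from compound 1 to compound 4 is expected to stay within the scatter, most likely again as a limit.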

Compound 4, half-maximal cytotoxic concentration: > 100 ug/mL
Compound 4 gave a limit, no number (the forecaster's own chance of this, stated with the estimate: 80%); the middle value does not contradict the limit.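

In this assay compound 4 gives > 100 ug/mL, which is a limit and not a number. Its steps to compound 1, compound 2 and compound 3 therefore cannot be read: the limit of > 100 ug/mL in this assay, at which 4 of the 4 values shown sit. The compounds shown leave open whether changing the aryl group on the shared core alters tolerance at all.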